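Ring size at the amine position: compound 2 to compound 4

The compounds below may be only part of what the source reports. "The series", "measured", "known", "first", "only" and "open" are said of these compounds alone.

Compound 2 `Cc1ccc2c(NCc3ccc(NC(=O)C4CCN(Cc5ccccc5)CC4)cc3)nc(N3CCCC3)nc2c1` gives in a functional assay on SV5A8 cells (Homo sapiens) for cytotoxicity (a lower number here means a stronger inhibitor, a higher number a weaker inhibitor), only a limit, > 7790 nM, namely (the limit of > 7790 nM in this assay, at which 1 of the 3 values shown sits). Compound 1 `Cc1ccc2c(NCc3ccc(NC(=O)C4CCN(Cc5cccc(F)c5)CC4)cc3)nc(N(C)C)nc2c1` likewise gives only a limit in this assay, > 4170 nM, namely (the limit of > 4170 nM in this assay, at which 1 of the 3 values shown sits). Compound 3 `Cc1ccc2c(NCc3ccc(NC(=O)C4CCN(Cc5cc(Cl)ccn5)CC4)cc3)nc(N(C)C)nc2c1` gives only a limit in this assay, > 5400 nM, namely (the limit of > 5400 nM in this assay, at which 1 of the 3 values shown sits). Compound 2 therefore stands at a limit among values that are all limits. For the measured compounds named here, the only step between measured compounds, a step that the two limits leave unreadable from compound 1 to compound 3, concerns another place and stays unreadable. Compound 4 `Cc1ccc2c(NCc3ccc(NC(=O)C4CCN(Cc5ccccc5)CC4)cc3)nc(N3CCCCCC3)nc2c1` differs from compound 2 by azepan-1-yl in place of pyrrolidin-1-yl on an aromatic carbon. Going by the values given here, no measured step bears on this change, so no direction can be read. Compound 4 is expected to give 8000 nM (3000 nM to 30000 nM) in this assay, most likely again a limit. The estimated step is a step that the limit leaves unreadable from compound 2 to compound 4.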

Compound 4, half-maximal inhibitory concentration: > 6880 nM
Compound 4 gave a limit, no number; the forecaster's own chance of this, stated with the estimate: 80%; the middle value is on the limit's open side.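

Compound 2 and compound 4 both give only limits in this assay; no step can be read for azepan-1-yl in place of pyrrolidin-1-yl. The compounds shown leave open whether ring size here changes the read-out, and whether any compound gives a number in this assay.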